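Cyclopropyl for ethyl on the triazole nitrogen

A few compounds are considered here, and "the series" means these few. Any claim that something is new, unique, unknown or untested is made for them only; others in the source may bear on it.

Of the compounds shown here, two have been measured in an assay on membranes from Jurkat cells for displacement of a labelled ligand from Sigma non-opioid intracellular receptor 1 (Homo sapiens), read by scintillation counting, with a stated time of 2 h; a higher number here means a weaker inhibitor, a lower number a stronger inhibitor. Compound 1 `Cn1nc(CN2CCCC2)nc1-c1ccc2ccsc2c1` gives 64 nM, while compound 2 `CCn1nc(CN2CCCC2)nc1-c1ccc(C(C)(C)C)cc1` gives 4.8 nM, the lowest of the two numbers, with compound 1 standing beyond the usual scatter above it. Compound 3 `CC(C)(C)c1ccc(-c2nc(CN3CCCC3)nn2C2CC2)cc1` differs from compound 2 by cyclopropyl in place of ethyl on an aromatic nitrogen. Within the data shown here, no measured pair tells what this change does, so the step is expected to be small, of no clear direction and within the scatter, a 1.0-fold higher number from compound 2 to compound 3 (0.02 log units; within the scatter). Compound 3 is therefore estimated at 5 nM, in a range from 2 nM to 15 nM.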

Compound 3, inhibition constant: 14 nM
Compound 3: the middle estimate sits 2.8-fold (0.45 log units) below what was measured; the measured number falls inside the stated range.
By their numbers in this assay, from the lowest: compound 2; then compound 3; then compound 1.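

This first pair differing in one place shows that the aromatic nitrogen is not indifferent to its substituent: in this assay cyclopropyl in place of ethyl gives a 2.9-fold higher number from compound 2 to compound 3 (0.46 log units; beyond the scatter) and so moves the number beyond the scatter. A single pair cannot separate the effect of the three-membered ring from that of the added carbon, and nothing available here explains the step. From the compounds shown here alone, whether an isopropyl or a propyl group on this nitrogen would stay closer to ethyl or to cyclopropyl remains open. Also open, going by these compounds, is whether the same step would appear with other groups in place of the tert-butylphenyl group.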